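Replacing the Benzylaminopropyl Arm of Compound 2

This account rests on a few compounds, and the source may have more. Where it says the series, first, only, none or still open, it means among the compounds named here.

Compounds measured so far:
compound 1 `c1ccc(CN(CCCCN(C[C@H]2Cc3ccccc3CN2)[C@H]2CCCc3cccnc32)Cc2ccccc2)cc1`, compound 2 `c1ccc(CNCCCCN(C[C@H]2Cc3ccccc3CN2)[C@H]2CCCc3cccnc32)cc1`, compound 3 `c1ccc2c(c1)CN[C@@H](CN(Cc1ccc(CNC3CCOCC3)cc1)[C@H]1CCCc3cccnc31)C2`.

In a functional assay on cells for antagonist activity at C-X-C chemokine receptor type 4 (Homo sapiens), read by fluorescence and calcium flux, with stated times of 25 min and 90 s (a lower number here means a stronger inhibitor, a higher number a weaker inhibitor), compound 1 gives only a limit, > 16700 nM. In this assay compound 2 gives 20.1 nM, and compound 3 gives 90.3 nM. Compound 2 therefore stands at the lowest of the two numbers, with compound 3 the nearest and higher, beyond the scatter, while compound 1 sits at a limit (the limit of > 16700 nM in this assay, at which 1 of the 3 values shown sits).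

Within the data shown here, the one step measured between neighbours is an at least 830-fold lower number from compound 1 to compound 2 (2.91 log units; beyond the scatter), where the change is hydrogen in place of benzyl on an amine nitrogen.

The unmeasured compound 4 `C(=C/CN(C[C@H]1Cc2ccccc2CN1)[C@H]1CCCc2cccnc21)\CNCC1CCOCC1` differs from compound 2 by a group of 11 heavy atoms (9 carbon, 1 nitrogen, 1 oxygen; one six-membered non-aromatic ring with 1 hetero atom) in place of a group of 11 heavy atoms (10 carbon, 1 nitrogen; one six-membered aromatic ring of carbon only), on a saturated chain carbon bound to an amine nitrogen. Compound 4 keeps an amine nitrogen bearing a hydrogen, as compound 2 does, so the large step seen from compound 1 to compound 2 does not argue for a loss of the same kind. Compound 3, which also carries a six-membered non-aromatic ring with one hetero atom, gives a higher number than compound 2, which hints at a moderate rise. Compound 4 is accordingly expected to show a step of a 2.2-fold higher number from compound 2 to compound 4 (0.35 log units; beyond the scatter) in this assay. The estimate for compound 4 is 45 nM, with a range from 12 nM to 180 nM.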

Compound 4, half-maximal inhibitory concentration: 24.2 nM
Compound 4: the middle estimate sits 1.9-fold (0.27 log units) above what was measured, within the range that was stated.
By their numbers in this assay, from the lowest: compounds 2 and 4 (each within the scatter of the next); then compound 3. At a limit, above all of these: compound 1.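

In this assay the exchange of arms gives a small step (a 1.2-fold higher number from compound 2 to compound 4 (0.08 log units; within the scatter)), so on this saturated chain carbon bound to an amine nitrogen, the 3-(benzylamino)propyl group can be replaced by the new group, with its six-membered non-aromatic ring with 1 hetero atom and its double bond outside aromatic rings, with no step beyond the scatter. The earlier pair showed only that the arm responds strongly to a change on its amine nitrogen (an at least 830-fold lower number from compound 1 to compound 2 (2.91 log units; beyond the scatter)), whereas this pair shows that, in an arm that keeps an amine nitrogen bearing a hydrogen, the six-membered aromatic ring of carbon only is not required for a number of this size. No measured property at hand bears on why the two arms read alike.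

Going by these compounds, the ring and the double bond enter together, so the part each plays remains open, and a saturated chain carrying the same ring, or a cyclohexyl ring in place of that ring, would separate them. Also open, on these data alone, is whether an amide or a carboxylic acid would be accepted in place of the amine in this arm.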